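Swapping the nitro-bearing ring for a fluorophenyl ring

The compounds below may be only part of what the source reports. "The series", "measured", "known", "first", "only" and "open" are said of these compounds alone.

Of the compounds shown here, two sharing the same core have been tested so far. Compound 1 `COc1ccc(-c2ccc3ncn(-c4cc(OC)c(OC)c(OC)c4)c3c2)cc1F` carries a 3-fluoro-4-methoxyphenyl group and, in a functional assay on SGC-7901 cells (Homo sapiens) for antiproliferative activity, read by MTT assay, with a stated time of 72 h (a higher number here means a weaker inhibitor, a lower number a stronger inhibitor), compound 1 gives 430 nM. Compound 2 `COc1cc(-n2cnc3ccc(-c4ccc([N+](=O)[O-])cc4)cc32)cc(OC)c1OC` instead carries a 4-nitrophenyl group, and in this assay compound 2 gives 79 nM. That single exchange produced a 5.4-fold lower number from compound 1 to compound 2 (0.74 log units; beyond the scatter), so compound 2 holds the lowest number of the two and is the stronger inhibitor of the pair.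

Compound 3 `COc1cc(-n2cnc3ccc(-c4cccc(F)c4)cc32)cc(OC)c1OC` is not yet measured. It differs from compound 2 in one place: 3-fluorophenyl in place of 4-nitrophenyl on an aromatic carbon.

Only one measured step bears on this change, the one from compound 1 to compound 2, where losing the 3-fluoro-4-methoxyphenyl group in favour of the 4-nitrophenyl group gave the drop described above. Compound 3 now gives up that same 4-nitrophenyl group, taking on a 3-fluorophenyl group which resembles the group of compound 1 but lacks its methoxy. The expectation for compound 3 is therefore a move back upward, a 3.8-fold higher number from compound 2 to compound 3 (0.58 log units; beyond the scatter), landing near compound 1. In this assay compound 3 is estimated at 300 nM, with a likely range from 100 nM to 900 nM.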

Compound 3, half-maximal inhibitory concentration: 2490 nM
Beside the measured number, compound 3's estimate is 8.3-fold (0.92 log units) below it; the whole stated range lies below it.
By their numbers in this assay, from the lowest: compound 2; then compound 1; then compound 3.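

In this assay, within the data shown here, the group on this aromatic carbon turns out to matter far more than the first pair of compounds could show: 3-fluorophenyl in place of 4-nitrophenyl gives a 32-fold higher number from compound 2 to compound 3 (1.50 log units; beyond the scatter) and is the largest step seen so far. The methoxy group also counts, since hydrogen in its place, with the fluorine kept, gives a 5.8-fold higher number from compound 1 to compound 3 (0.76 log units; beyond the scatter) and shows that a fluorophenyl group's standing here depends on what else the ring carries. Nothing available explains either step.

The step from compound 2 to compound 3 changes both the substituent and where it sits on the ring, so these compounds cannot tell how much of the loss comes from giving up the nitro group and how much from the new placement. A plain phenyl, a 4-fluorophenyl or a 3-nitrophenyl group would separate those two changes, while a 4-aminophenyl group or a 4-carboxyphenyl group would show whether anything other than a nitro group can serve at this spot.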